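Carboxy to vinyl on the side chain

The compounds below may be only part of what the source reports. "The series", "measured", "known", "first", "only" and "open" are said of these compounds alone.

Of the compounds shown here, three sharing one core have been measured in a functional assay on LNCaP cells (Homo sapiens) for antiproliferative activity; on this read-out higher numbers stand for weaker inhibition and lower numbers for stronger inhibition. Compound 1 `Cn1ncc(Cl)c1-c1cc(C(=O)N[C@@H]2CN[C@H](CCCO)C[C@H]2c2ccc(Cl)c(Cl)c2)oc1Cl` gives 210 nM. Compound 2 `Cn1ncc(Cl)c1-c1cc(C(=O)N[C@@H]2CN[C@H](CC(N)=O)C[C@H]2c2ccc(Cl)c(Cl)c2)oc1Cl` gives 160 nM. Compound 3 `Cn1ncc(Cl)c1-c1cc(C(=O)N[C@@H]2CN[C@H](CC(=O)O)C[C@H]2c2ccc(Cl)c(Cl)c2)oc1Cl` gives 640 nM, the highest number of the three, and its gaps to both others lie beyond the scatter.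

Compound 4 `C=CC[C@@H]1C[C@@H](c2ccc(Cl)c(Cl)c2)[C@H](NC(=O)c2cc(-c3c(Cl)cnn3C)c(Cl)o2)CN1` is the next to be read. Its difference from compound 3 is vinyl in place of carboxy on a saturated chain carbon bound to a saturated ring carbon, or, cut one bond further out, carboxymethyl to allyl.

All three measured steps fall at this same place. Two lead into the carboxy compound and are modest: a 3.0-fold higher number from compound 1 to compound 3 (0.48 log units; beyond the scatter) and a 4.0-fold higher number from compound 2 to compound 3 (0.60 log units; beyond the scatter). The third, a 1.3-fold lower number from compound 1 to compound 2 (0.12 log units; within the scatter), stays within the scatter, so the two compounds without carboxy read alike. Compound 4 also lacks carboxy, so a step of similar modest size is expected, running towards a lower number. Going by the values given here, no measured compound carries allyl, and this read-across rests on three compounds only, so the range is kept wide.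

The expected step is a 3.8-fold lower number from compound 3 to compound 4 (0.58 log units; beyond the scatter).

For compound 4 the estimate is 170 nM, with an expected range of 60 nM to 480 nM.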

Compound 4, half-maximal inhibitory concentration: 160 nM
Compound 4: the middle estimate sits 1.1-fold (0.03 log units) above what was measured, and the stated range covers the measured number.
By their numbers in this assay, from the lowest: compounds 2, 4 and 1 (each within the scatter of the next); then compound 3.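

At the saturated chain carbon bound to a saturated ring carbon, vinyl in place of carboxy gives a 4.0-fold lower number from compound 3 to compound 4 (0.60 log units; beyond the scatter) in this assay, so the gap seen earlier between compound 3 and the compounds without carboxy now extends to a side chain ending in a plain hydrocarbon. Vinyl enters with 0 hydrogen-bond donors and 0 hydrogen-bond acceptors, yet the steps to it from the carbamoyl and 2-hydroxyethyl compounds are no change at the digits printed from compound 2 to compound 4 (within the scatter) and a 1.3-fold lower number from compound 1 to compound 4 (0.12 log units; within the scatter); among these four compounds, a hydrogen-bond donor or acceptor in this side chain is therefore not required for a number in the range of compounds 1, 2 and 4, and compound 3 alone stands apart. Nothing measured here explains why the carboxy compound differs from the other three.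

Open, as far as these compounds go, is whether a primary amine or a methyl ester at this place would read with compounds 1, 2 and 4 or with compound 3. Also open, from the compounds shown here alone, is whether a longer saturated hydrocarbon chain or a phenyl group would stay within the scatter of compound 4.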